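Trans-cyclohexyl series: inverting one piperidine centre

This account rests on a few compounds, and the source may have more. Where it says the series, first, only, none or still open, it means among the compounds named here.

Compound 1 `CCS(=O)(=O)NC1CCCN(C(C)=O)C1COC1CCC(C(C)C)CC1` is the series member drawn without configuration, and in a functional assay on CHO-K1 cells for agonist activity at Orexin receptor type 2 (Homo sapiens), read by FLIPR and calcium flux (on this read-out lower numbers stand for an effect already at smaller amounts and higher numbers for an effect only at larger amounts of compound), compound 1 gives 570 nM. Compound 2 `CCS(=O)(=O)N[C@H]1CCCN(C(C)=O)[C@H]1CO[C@H]1CC[C@@H](C(C)C)CC1` carries all four centres defined, and in this assay compound 2 gives 270 nM; the step of a 2.1-fold lower number from compound 1 to compound 2 (0.32 log units; beyond the scatter) is modest, with the drawn configurations the fact that one of compounds 1 and 2 is drawn with a defined configuration and the other without, at the place where they differ as the only difference. Compound 3 `CCS(=O)(=O)N[C@H]1CCCN(C(C)=O)[C@H]1CO[C@H]1CC[C@H](C(C)C)CC1` is reported in this assay only as a limit, > 30000 nM. Compound 3 therefore stands at the weak end of the numbers shown, since an at least 110-fold higher number from compound 2 to compound 3 (2.04 log units; beyond the scatter) and an at least 52-fold higher number from compound 1 to compound 3 (1.72 log units; beyond the scatter) are both large, resting on the configuration drawn at the cyclohexyl ring the fact that compounds 2 and 3 differ only in the configuration as drawn and (the fact that one of compounds 1 and 3 is drawn with a defined configuration and the other without, at the place where they differ).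

Compound 4 `CCS(=O)(=O)N[C@@H]1CCCN(C(C)=O)[C@H]1CO[C@H]1CC[C@H](C(C)C)CC1` is not yet measured. Relative to compound 3 the change is the two compounds have the same atoms and bonds and differ only in configuration as drawn: 1 of 4 stereo elements differ; a stereocentre at a saturated ring carbon is drawn S in compound 3 and R in compound 4. Going by the values given here, the cyclohexyl configuration of compound 3 is kept, so the large loss seen in the step from compound 2 to compound 3 is the step that bears most on this one; the piperidine centre changed here has no separate measured step. The expectation is therefore for compound 4 to remain weak, and a step of an at least 2.0-fold lower number from compound 3 to compound 4 (0.30 log units; that floor lies within the scatter) is estimated, with a real chance that this assay again reports only a limit. Compound 4 is estimated at 15000 nM, within a range from 2000 nM to 30000 nM.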

Compound 4, half-maximal effective concentration: > 30000 nM
Compound 4: no number, only a limit (the forecaster's own chance of this, stated with the estimate: 55%); at least 2.0-fold (0.30 log units) between middle value and limit.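

Compound 4 is reported in this assay only as a limit, > 30000 nM: the limit of > 30000 nM in this assay, at which 2 of the 4 values shown sit. The step between compound 3 and compound 4 cannot be read, with a limit on each side, so inverting this piperidine centre while keeping the cyclohexyl configuration of compound 3 brings no measurable effect into the range of the assay: the fact that compounds 3 and 4 differ only in the configuration as drawn. Compound 4 also sits at the weak end against the two compounds with numbers, with an at least 110-fold higher number from compound 2 to compound 4 (2.04 log units; beyond the scatter) and an at least 52-fold higher number from compound 1 to compound 4 (1.72 log units; beyond the scatter) both large, although the first of these steps changes three stereo elements at once and does not isolate the piperidine centre: the fact that compounds 2 and 4 differ only in the configuration as drawn.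

Going by these compounds alone, how much this piperidine centre matters under the cyclohexyl configuration of compound 2 stays open, since the only compounds that differ at this centre alone both sit at the limit. Also open, from the compounds shown here alone, is whether a tert-butyl group in place of the isopropyl group on the cyclohexyl ring would show the same dependence on configuration.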